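Thiophen-2-yl in place of 3-chlorophenyl: compound 4

The source may hold more compounds than are shown below. What is called first, only, known or untested is meant among the compounds shown, and "the series" means these compounds.

Measured so far in a functional assay on PC-3 cells (Homo sapiens) for inhibition, read by sulforhodamine B assay, with a stated time of 48 h; on this read-out higher numbers stand for weaker inhibition of growth and lower numbers for stronger inhibition of growth:
- compound 1, `CC1=CC[C@H](C(C)(C)NC(=S)NN)CC1`: compound 1 gives 44500 nM.
- compound 2, `COc1ccc(/C=N/NC(=S)NC(C)(C)[C@H]2CC=C(C)CC2)cc1`: compound 2 gives < 40 nM, which is a limit of the assay and not a number.
- compound 3, `CC1=CC[C@H](C(C)(C)NC(=S)N/N=C/c2cccc(Cl)c2)CC1`: compound 3 gives 600 nM.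

Among the numbers shown, compound 3 stands lowest; its nearest neighbour is compound 1, whose number lies far higher. The remaining value, that of compound 2, is a limit (the limit of < 40 nM in this assay, at which 1 of the 3 values shown sits). Compound 4, `CC1=CC[C@H](C(C)(C)NC(=S)N/N=C/c2cccs2)CC1`, differs from compound 3 in one place: thiophen-2-yl in place of 3-chlorophenyl on a carbon with a double bond to nitrogen. Going by the values given here, only one measured step bears on this change, an exchange of the aryl group on the carbon with a double bond to nitrogen, which gave an at least 15-fold higher number from compound 2 to compound 3 (1.17 log units; beyond the scatter). That step shows the aryl group alone can shift the number a long way in this assay, but which way a thiophen-2-yl group shifts it, nothing measured tells. Compound 4 is therefore expected close to compound 3, with a broad range. The expected step is a 1.2-fold lower number from compound 3 to compound 4 (0.08 log units; within the scatter). The estimate for compound 4 is 500 nM, with a range from 80 nM to 3000 nM.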

Compound 4, concentration for 50% growth inhibition: 17800 nM
Estimate against measurement, compound 4: 36-fold (1.55 log units) below; measured number outside the range, above it.
By their numbers in this assay, from the lowest: compound 3; then compound 4; then compound 1. At a limit, below all of these: compound 2.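

In this assay, the choice of aromatic ring on a carbon with a double bond to nitrogen now proves able to remove most of the growth inhibition, since thiophen-2-yl in place of 3-chlorophenyl gives a 30-fold higher number from compound 3 to compound 4 (1.47 log units; beyond the scatter). Against compound 1, which has no aromatic ring at all, the thiophen-2-yl group retains only a 2.5-fold lower number from compound 1 to compound 4 (0.40 log units; beyond the scatter), while its exchange for 4-methoxyphenyl corresponds to an at least 440-fold higher number from compound 2 to compound 4 (2.64 log units; beyond the scatter). Compound 2, at the start of that last step, stands at a limit of the assay and not a number: the limit of < 40 nM in this assay, at which 1 of the 4 values shown sits.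

How an unsubstituted phenyl, a furan-2-yl or a pyridin-2-yl group would stand on this carbon remains open, so the compounds shown do not separate the effect of ring size from that of the sulfur atom. Also open, on these data alone, is how far the true value of compound 2 lies from its limit.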